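Butyl ester as the next step from compound 2

A few compounds are considered here, and "the series" means these few. Any claim that something is new, unique, unknown or untested is made for them only; others in the source may bear on it.

Compound 1 `COC(=O)C(C)ON1C(=O)c2ccccc2C1=O` gives 64% in a functional assay on the whole organism for inhibition, with Lepidium sativum as the target, tested at 1 ppm; on this read-out higher numbers stand for more inhibition of growth at the one concentration tested and lower numbers for less inhibition of growth. Compound 2 `CC(C)OC(=O)C(C)ON1C(=O)c2ccccc2C1=O` gives 51%, the second highest of the three numbers measured; its nearest neighbour is compound 1, with a number 13 percentage points lower from compound 1 to compound 2 (beyond the scatter), and its furthest is compound 3 `CCOC(=O)C(CC)ON1C(=O)c2ccccc2C1=O`, which gives 0%. Compound 3 differs from compound 2 in two places at once, so its value cannot be tied to the ester group alone.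

Compound 4 `CCCCOC(=O)C(C)ON1C(=O)c2ccccc2C1=O` differs from compound 2 by butyl in place of isopropyl on an oxygen next to a carbonyl group. Among the measured compounds shown here, the only measured step that touches the same place is the one from compound 1 to compound 2, where isopropyl in place of methyl on an oxygen next to a carbonyl group lowered the read-out modestly, a number 13 percentage points lower from compound 1 to compound 2 (beyond the scatter). Going on from isopropyl to butyl is expected to move the read-out in the same direction by a similar or smaller amount, possibly not beyond the scatter: a number 9 percentage points lower from compound 2 to compound 4 (within the scatter). Compound 4 is therefore estimated at 42%, within 20% to 62%.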

Compound 4, percent growth inhibition at one concentration: 59%
For compound 4 the middle estimate is 17 percentage points below the measured one; measured number inside the range.
By their numbers in this assay, from the lowest: compound 3; then compounds 2, 4 and 1 (each within the scatter of the next, the first and the last beyond it).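

In this assay butyl on this oxygen cannot be told apart from isopropyl (a number 8 percentage points higher from compound 2 to compound 4 (within the scatter)), nor from the methyl ester of compound 1 (a number 5 percentage points lower from compound 1 to compound 4 (within the scatter)). The step from compound 1 to compound 2 therefore does not extend into a trend with the size of the ester group: compound 4 carries the larger group, yet it lies within the scatter of both neighbours. No supporting data bear on the reason for this result.

Still open, going by these compounds, is whether the position also keeps the read-out with a benzyl ester or a free carboxylic acid in place of the ester. On these data alone, the effect of an ethyl group on the saturated chain carbon, taken alone with the ester group held constant, also remains open.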